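The compounds below may be only part of what the source reports. "The series", "measured", "known", "first", "only" and "open" are said of these compounds alone.

Of the compounds shown here, two sharing one core have been measured so far. In a physicochemical assay for solubility, at pH 7.4 (on this read-out higher numbers stand for higher solubility and lower numbers for lower solubility), compound 1 `O=C(N[C@H]1CN(S(=O)(=O)c2ccccc2)C[C@@H]1C(=O)N[C@H]1CCCNC1)c1cc(-c2ccc(Cl)cc2)on1` gives 12000 nM, and compound 2 `O=C(N[C@H]1CN(S(=O)(=O)c2ccccc2)C[C@@H]1C(=O)N[C@H]1CCCNC1)c1cc(-c2ccccc2Cl)on1` gives 12000 nM, so compound 2 stands level with compound 1. The step that joins them, 2-chlorophenyl in place of 4-chlorophenyl on an aromatic carbon, shows no change at the digits printed from compound 1 to compound 2 (within the scatter).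

Compound 3 `CC(=O)N1CCC[C@H](NC(=O)[C@H]2CN(S(=O)(=O)c3ccccc3)C[C@@H]2NC(=O)c2cc(-c3ccccc3Cl)on2)C1` is now to be read in this assay. It keeps everything in compound 2 except for acetyl in place of hydrogen on an amine nitrogen in a ring, which turns piperidin-3-yl into 1-acetylpiperidin-3-yl: acetyl in place of hydrogen on an amine nitrogen in a ring. Among the measured compounds shown here, the one measured step lies at a different place in the molecule, so it bears on this change only weakly, and no measured pair alters this nitrogen. The starting point is therefore compound 2 at 12000 nM, with wide margins on either side. A modest fall is expected, though a result within the scatter would not be surprising. The expected size of the change is a 1.7-fold lower number from compound 2 to compound 3 (0.23 log units; within the scatter). The estimated value for compound 3 is 7000 nM, with an expected range from 2000 nM to 20000 nM.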

Compound 3, solubility: < 500 nM
Compound 3: no number, only a limit; the forecaster's own chance of this, stated with the estimate: 10%; at least 14-fold (1.14 log units) between middle value and limit.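

The ring nitrogen of piperidin-3-yl proves to be a sensitive place in this assay: turning it into 1-acetylpiperidin-3-yl gives an at least 24-fold lower number from compound 2 to compound 3 (1.38 log units; beyond the scatter), whereas the earlier change on the aromatic ring, 2-chlorophenyl in place of 4-chlorophenyl, gave no change at the digits printed from compound 1 to compound 2 (within the scatter). Compound 3 gives < 500 nM, which is a limit of the assay and not a number. The true size of the step therefore stays unknown on its far side, and the step marks only how large it must at least be, with compound 3 the only one of the compounds shown to reach this limit: the limit of < 500 nM in this assay, at which 1 of the 3 values shown sits.

The compounds shown leave open whether the step follows from losing the hydrogen on this nitrogen or from the acetyl itself, since a methyl group, a longer acyl chain such as propionyl or a sulfonyl group on the same nitrogen would be needed to separate the two. They also leave open whether acetyl on this nitrogen would give a step of like size with the 4-chlorophenyl of compound 1, and this single pair says nothing about why the read-out moves.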